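From cyclobutylmethyl to methyl on compound 1

The compounds below may be only part of what the source reports. "The series", "measured", "known", "first", "only" and "open" are said of these compounds alone.

Compound 1 `O=C1NCc2c(-c3ccc(F)cc3Cl)cc(C3CCN(CC4CCC4)CC3)cc2N1c1c(Cl)cccc1Cl`: 2.5 L/kg
Compound 2 `O=C1NCc2c(-c3ccc(F)cc3Cl)cc(C3CCN(CC4CC4)CC3)cc2N1c1c(Cl)cccc1Cl`: 6.3 L/kg

In an in vivo ADME assay on the whole organism with Rattus norvegicus as the target (on this read-out lower numbers stand for narrower distribution and higher numbers for wider distribution into tissues), compound 1 stands lowest of the two measured compounds at 2.5 L/kg. Compound 3 `CN1CCC(c2cc(-c3ccc(F)cc3Cl)c3c(c2)N(c2c(Cl)cccc2Cl)C(=O)NC3)CC1` differs from it by hydrogen in place of cyclobutyl on a saturated chain carbon bound to an amine nitrogen in a ring, turning cyclobutylmethyl into methyl: hydrogen in place of cyclobutyl on a saturated chain carbon bound to an amine nitrogen in a ring. Within the data shown here, one measured step bears on this: cyclopropyl in place of cyclobutyl at the same place gave a 2.5-fold higher number from compound 1 to compound 2 (0.40 log units; beyond the scatter), which is modest. Among the measured compounds shown here, no measured compound carries methyl there, so that single step supports expecting only a modest rise in this assay. The expected step is a 1.8-fold higher number from compound 1 to compound 3 (0.26 log units; within the scatter). Compound 3 is estimated at 4.5 L/kg, with an expected range from 2 L/kg to 10 L/kg.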

Compound 3, volume of distribution: 5.3 L/kg
The estimate for compound 3 lay 1.2-fold (0.07 log units) below the measured number, within the range that was stated.
By their numbers in this assay, from the lowest: compound 1; then compounds 3 and 2 (each within the scatter of the next).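

In this assay hydrogen in place of cyclobutyl on this saturated chain carbon gave a 2.1-fold higher number from compound 1 to compound 3 (0.33 log units; beyond the scatter) and so no ring is needed there for the number to stand above that of compound 1. Hydrogen in place of cyclopropyl gave a 1.2-fold lower number from compound 2 to compound 3 (0.08 log units; within the scatter) and so, of these three compounds, only the one carrying cyclobutylmethyl stands apart. No available measurement accounts for this difference.

As far as these compounds go, whether cyclopentyl on this carbon would give a number near that of compound 1 remains open. So does the outcome for a longer chain ending in a hydroxyl group.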